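This account rests on a few compounds, and the source may have more. Where it says the series, first, only, none or still open, it means among the compounds named here.

Compound 1 `COc1ccccc1/C=C/C(=O)OC/C=C/c1cc(OC)c(OC)cc1OC` gives 100% in a functional assay on the whole organism (strain Kunming) with Mus musculus as the target, with a stated time of 0.5 h, at a dose of 100 mg/kg by the intraperitoneal route; a higher number here means a weaker effect of the compound at the dose given, a lower number a stronger effect. Compound 2 `COc1cc(OC)c(OC)cc1/C=C/COC(=O)/C=C/c1ccccc1C(F)(F)F` gives 100% in this assay, and the step of no change at the digits printed from compound 1 to compound 2 (within the scatter) leaves it level with compound 1. Compound 3 `COc1ccc(/C=C/C(=O)OC/C=C/c2cc(OC)c(OC)cc2OC)cc1` differs from compound 2 by 4-methoxyphenyl in place of 2-(trifluoromethyl)phenyl on a double-bonded chain carbon bound to a double-bonded chain carbon. Within the data shown here, no measured step touches this aryl group; the only step known, no change at the digits printed from compound 1 to compound 2 (within the scatter), was flat, so for compound 3 a step of no change at the digits printed from compound 2 to compound 3 (within the scatter) of no change beyond the scatter is expected. Compound 3 is estimated at 100%, within 85% to 100%.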

Compound 3, a percentage reported as activity, at one dose (the size of the read-out at that dose, not a potency): 100%
Estimate against measurement, compound 3: no gap at the digits printed; the range from low to high includes it.
By their numbers in this assay, from the lowest: compounds 1, 2 and 3 (each within the scatter of the next).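

Compound 3 places a 4-methoxyphenyl on a double-bonded chain carbon bound to a double-bonded chain carbon, and this assay shows no change at the digits printed from compound 2 to compound 3 (within the scatter) and no change at the digits printed from compound 1 to compound 3 (within the scatter). The 2-(trifluoromethyl)phenyl, 2-methoxyphenyl and 4-methoxyphenyl groups therefore cannot be told apart at this place in this read-out at the dose given. No available evidence bears on this result. Still open, from the compounds shown here alone, is whether an aryl group carrying an amine or a carboxylic acid at this place would lower the number. Also open, going by these compounds, is whether an amide in place of the ester in the shared core would do so.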